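The source may report more compounds than this note shows. Statements on the series, on what has been measured and on what is new or still open speak of the compounds shown alone.

Working notes on the series, read in an ADME assay on HEK293 cells (Homo sapiens) for antiproliferative activity, read by MTT assay, with a stated time of 48 h; a lower number here means a stronger inhibitor, a higher number a weaker inhibitor. Compound 1 `O=C(/C=C/c1c[nH]c2ccccc12)c1ccncc1` returns no number, only a limit of > 150000 nM. Compound 2 `COc1ccc(S(=O)(=O)n2cc(/C=C/C(=O)c3ccncc3)c3ccccc32)cc1`, with 4-methoxyphenyl on a sulfonyl sulfur, likewise returns only a limit of > 150000 nM. No number therefore fixes where compound 2 stands, and the record so far comes down to the limit of > 150000 nM in this assay, at which 2 of the 2 values shown sit.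

The next compound is compound 3 `O=C(/C=C/c1cn(S(=O)(=O)c2ccc(Cl)cc2Cl)c2ccccc12)c1ccncc1`, with 2,4-dichlorophenyl in place of 4-methoxyphenyl on a sulfonyl sulfur. Among the measured compounds shown here, no measured pair shows a change of this kind, so there is no step to scale from.

With compound 2 at > 150000 nM, which is a limit, no shift beyond the scatter is expected in this assay, in either direction, and a further limit is the most likely report. The expected a number no higher from compound 2 to compound 3 (the limit leaves the size open) is small. For compound 3 the estimate is 150000 nM, with an expected range from 60000 nM to 300000 nM.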

Compound 3, half-maximal inhibitory concentration: > 150000 nM
Compound 3: only a limit was reported; the forecaster's own chance of this, stated with the estimate: 80%; the middle value lies on the limit itself.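

Compound 2 and compound 3 are both reported only as limits in this assay, so no step can be read between them for 2,4-dichlorophenyl in place of 4-methoxyphenyl on a sulfonyl sulfur. The compounds shown leave open whether any member of the series gives a measurable value, as the record stands at a single limit: the limit of > 150000 nM in this assay, at which 3 of the 3 values shown sit.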